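Ethyl for trifluoromethyl, with a single measured value

The source may hold more compounds than are shown below. What is called first, only, known or untested is meant among the compounds shown, and "the series" means these compounds.

Going by the values given here, in a functional assay on DERL7 cells (Homo sapiens) for antiproliferative activity, with a stated time of 72 h (on this read-out lower numbers stand for stronger inhibition and higher numbers for weaker inhibition), compound 1 (`NC(=O)c1cc(-c2ccnc(N)n2)[nH]c1-c1cc(C(F)(F)F)ccc1Cl`) gives 1880 nM as the only number so far. Compound 2 (`NC(=O)c1cc(-c2ccnc(N)n2)[nH]c1-c1cc(C(F)(F)F)ccc1C(F)(F)F`) carries the entry "not determined" (no result reported) in this assay and therefore offers no starting value on the scale. Compound 3 (`CCc1ccc(C(F)(F)F)cc1-c1[nH]c(-c2ccnc(N)n2)cc1C(N)=O`) differs from compound 2 by a single change: ethyl in place of trifluoromethyl on an aromatic carbon, ortho to a large group and para to a trifluoromethyl group. Among the compounds with values here, no measured step shows the size of such a change. With compound 1 at 1880 nM as the sole reference, no step beyond the scatter is expected in this assay, and no direction is favoured. Compound 3 is estimated at 1500 nM, with 500 nM to 5000 nM as the expected range.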

Compound 3, half-maximal inhibitory concentration: 1470 nM
Beside the measured number, compound 3's estimate is 1.0-fold (0.01 log units) above it; measured number inside the range.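

In this assay, the position ortho to a large group and para to a trifluoromethyl group now has two readable occupants, chloro and ethyl, and exchanging them gives a 1.3-fold lower number from compound 1 to compound 3 (0.11 log units; within the scatter). On the shared core, this read-out therefore does not separate chloro from ethyl at this position, so an alkyl group here retains a measurable value in the same range as the halogen. The step from trifluoromethyl to ethyl cannot be read, as compound 2 has no number, and no evidence bearing on the result is at hand.

From the compounds shown here alone, whether an amine, a carboxylic acid or a longer chain such as propyl at this position would move the number beyond the scatter remains open. Also open is any replacement of the trifluoromethyl group that all the compounds shown carry.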